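The source may report more compounds than this note shows. Statements on the series, on what has been measured and on what is new or still open speak of the compounds shown alone.

Within the data shown here, compound 2 `Cc1ccnc(NC(=O)c2ccccc2C)c1` gives 129 uL/min in an ADME assay (liver) for metabolic stability, with Liver microsome (Homo sapiens) as the target, read by LC-MS, using microsomes, with a stated time of 60 min, tested at 1 uM (a lower number here means slower removal, a higher number faster removal of the compound), the smaller of the two numbers so far, though the gap to compound 1 `Cc1c(F)cccc1C(=O)Nc1cc(Cl)ccn1`, which gives 254 uL/min, is within the scatter, so the two are not told apart. Compound 3 `Cc1ccnc(NC(=O)c2cccc(F)c2C)c1` differs from compound 2 by fluoro in place of hydrogen on an aromatic carbon. Among the measured compounds shown here, no step between measured compounds that differ in one place exists, and compound 1 differs from compound 2 in two places, so the change cannot be read from those values. Only a small step, within the scatter and in either direction, is expected in this assay. Compound 3 is estimated at 160 uL/min, from 80 uL/min to 320 uL/min, an expected step of a 1.2-fold higher number from compound 2 to compound 3 (0.09 log units; within the scatter).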

Compound 3, intrinsic clearance in a liver preparation (reported as CLH), per the amount of preparation that the assay uses in the Liver microsome assay: 237 uL/min
Estimate against measurement, compound 3: 1.5-fold (0.17 log units) below, within the range that was stated.
By their numbers in the Liver microsome assay, from the lowest: compounds 2, 3 and 1 (each within the scatter of the next).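

In the Liver microsome assay, fluoro in place of hydrogen on an aromatic carbon, ortho to a methyl group, gives a 1.8-fold higher number from compound 2 to compound 3 (0.26 log units; within the scatter), and methyl in place of chloro gives a 1.1-fold lower number from compound 1 to compound 3 (0.03 log units; within the scatter), so neither change can be told apart from the scatter. In a physicochemical assay for solubility, read by nephelometry, measured as kinetic solubility, at pH 6.5, tested at 10 mg/mL (on this read-out lower numbers stand for lower solubility and higher numbers for higher solubility), compound 2 gives 25 ug/mL and compound 3 gives 25 ug/mL, which is no change at the digits printed from compound 2 to compound 3 (within the scatter). No measurement here offers an explanation for these numbers. Going by these compounds, whether a different group on this aromatic carbon, such as an amine or a carboxylic acid, would move either read-out beyond the scatter stays open.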